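Phenyl in Place of Propyl on the Carbonyl Carbon

The source may report more compounds than this note shows. Statements on the series, on what has been measured and on what is new or still open speak of the compounds shown alone.

Compound 1, `Cc1[nH]nc(N)c1-c1cccc(Cl)c1`, gives 93400 nM in an assay on Sf9 cells for inhibition of inhibitor of nuclear factor kappa-B kinase subunit epsilon (Homo sapiens), read by ADP-Glo, with a stated time of 60 min; a higher number here means a weaker inhibitor, a lower number a stronger inhibitor.
Compound 2, `Cc1[nH]nc(N)c1-c1cccc(OC(F)(F)F)c1`, gives > 100000 nM in this assay, which is a limit of the assay rather than a number.
Compound 3, `CCCC(=O)n1nc(C)c(-c2ccc(Cl)c(Cl)c2)c1N`, gives > 100000 nM in this assay, likewise a limit.

Compound 3 thus stands at the limit of > 100000 nM in this assay, at which 2 of the 3 values shown sit, with no exact number of its own. The unmeasured compound 4, `Cc1nn(C(=O)c2ccccc2)c(N)c1-c1ccc(Cl)c(Cl)c1`, differs from compound 3 by phenyl in place of propyl on a carbonyl carbon. Among the compounds with values here, the only measured step, an at least 1.0-fold higher number from compound 1 to compound 2 (0.02 log units; that floor lies within the scatter), concerns a group on the aromatic ring rather than the carbonyl carbon and lies within the scatter, so no measured step bears directly on this change. Compound 4 is therefore expected to remain weak, with an expected step of a number no higher from compound 3 to compound 4 (the limit leaves the size open). Compound 4 is estimated at 100000 nM, within a range from 30000 nM to 300000 nM.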

Compound 4, half-maximal inhibitory concentration: > 100000 nM
Compound 4 ended at the assay's limit; the forecaster's own chance of this, stated with the estimate: 70%; the middle value lies on the limit itself.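

No step can be read from compound 3 to compound 4, since each stands only at a limit and not at a number: the limit of > 100000 nM in this assay, at which 3 of the 4 values shown sit. As far as these compounds go, how phenyl and propyl on the carbonyl carbon compare in this assay stays open.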